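Indolyl in place of pyrrolyl on the enone carbonyl

A few compounds are considered here, and "the series" means these few. Any claim that something is new, unique, unknown or untested is made for them only; others in the source may bear on it.

Compound 1 `COc1ccc(C(=O)/C=C/c2nc3ccccc3cc2-c2ccc(OC)cc2)cc1` gives in a functional assay on H184B5F5/M10 cells (Homo sapiens) for antiproliferative activity, read by XTT assay, with a stated time of 72 h (a lower number here means a stronger inhibitor, a higher number a weaker inhibitor), a limit of > 10000 nM.
Compound 2 `COc1ccc(-c2cc3ccccc3nc2/C=C/C(=O)c2ccco2)cc1` gives in this assay 6240 nM.
Compound 3 `COc1ccc(-c2cc3ccccc3nc2/C=C/C(=O)c2ccc[nH]2)cc1` gives in this assay a limit of > 10000 nM.

Compound 3 stands at the limit of this assay, and that is the position at which the limit of > 10000 nM in this assay, at which 2 of the 3 values shown sit, is also reached by compound 1; only compound 2 returns a number. The step of an at least 1.6-fold higher number from compound 2 to compound 3 (0.20 log units; that floor lies within the scatter) has a floor that lies within the scatter, and the step that the two limits leave unreadable from compound 1 to compound 3 cannot be read at all. The step of an at least 1.6-fold lower number from compound 1 to compound 2 (0.20 log units; that floor lies within the scatter) likewise rests on a floor within the scatter.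

Compound 4 `COc1ccc(-c2cc3ccccc3nc2/C=C/C(=O)c2c[nH]c3ccccc23)cc1` differs from compound 3 by 1H-indol-3-yl in place of 1H-pyrrol-2-yl on a carbonyl carbon. Among the measured compounds shown here, no measured step involves the 1H-indol-3-yl group, so the only bearing comes from the three steps above, all of which are at or below the scatter or unreadable. Compound 4 is therefore expected to sit close to compound 3, with the step of an at least 1.2-fold lower number from compound 3 to compound 4 (0.09 log units; that floor lies within the scatter) estimated as small. Compound 4 is estimated at 8000 nM, in a range from 2000 nM to 30000 nM, with a fair chance that this assay reports only a limit for it.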

Compound 4, half-maximal inhibitory concentration: > 10000 nM
Compound 4 was reported as a limit; the forecaster's own chance of this, stated with the estimate: 55%; at least 1.2-fold (0.09 log units) between middle value and limit.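

Replacing 1H-pyrrol-2-yl on the carbonyl carbon with 1H-indol-3-yl, which adds a six-membered aromatic ring of carbon only, still yields no number: in this assay compound 4 gives > 10000 nM, which is a limit of the assay. Among the compounds shown here, the steps to compound 4 from compound 3 and from compound 1 cannot be read, and the only readable step is an at least 1.6-fold higher number from compound 2 to compound 4 (0.20 log units; that floor lies within the scatter). Of the four groups tried at this position, only furan-2-yl returns a number, and the other three share one limit: the limit of > 10000 nM in this assay, at which 3 of the 4 values shown sit.

As far as these compounds go, how far compound 1, compound 3 and compound 4 lie beyond that limit remains open. Also open, from the compounds shown here alone, is whether a thiophen-2-yl group or a pyridin-2-yl group on this carbonyl carbon would return a number, as furan-2-yl does.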